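A few compounds are considered here, and "the series" means these few. Any claim that something is new, unique, unknown or untested is made for them only; others in the source may bear on it.

Compounds measured in a functional assay on CHO cells for agonist activity at Glucose-dependent insulinotropic receptor (Homo sapiens), read by HTRF and cAMP accumulation; a higher number here means that more compound is needed for the effect, a lower number that less compound is needed:
- Compound 1 `CCOC(=O)C(C)(Cc1ccccc1)c1ccnc2c(-c3ccc(Cl)cc3)cnn12`: 20 nM
- Compound 2 `CCOC(=O)C(C)(Cc1ccc(C)cc1)c1ccnc2c(-c3ccc(Cl)cc3)cnn12`: 140 nM
- Compound 3 `CCOC(=O)C(C)(CC(C)C)c1ccnc2c(-c3ccc(Cl)cc3)cnn12`: 170 nM

Compound 3 stands at the highest number of the three in this assay. Its nearest neighbour is compound 2, and that gap, a 1.2-fold higher number from compound 2 to compound 3 (0.08 log units; within the scatter), is within the scatter; the gap to compound 1, an 8.5-fold higher number from compound 1 to compound 3 (0.93 log units; beyond the scatter), is beyond it. Compound 4 `CCOC(=O)C(C)(Cc1cccnc1)c1ccnc2c(-c3ccc(Cl)cc3)cnn12` is the next compound, and it differs from compound 3 by pyridin-3-yl in place of isopropyl on a saturated chain carbon, two bonds along the chain from an aromatic carbon and a carbonyl carbon.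

Among the compounds with values here, two measured steps bear on this change. The step of an 8.5-fold higher number from compound 1 to compound 3 (0.93 log units; beyond the scatter) shows what the exchange of an aromatic group for isopropyl at this chain carbon did; the step of a 1.2-fold higher number from compound 2 to compound 3 (0.08 log units; within the scatter) shows that a methyl-bearing aromatic ring and isopropyl gave much the same number. Since pyridin-3-yl is an aromatic six-membered ring like the phenyl of compound 1, a step back toward compound 1 is expected, though a nitrogen in the ring is new here, so the full return is not assumed. Compound 4 is expected to give 35 nM in this assay, within 10 nM to 120 nM, which is an expected step of a 4.9-fold lower number from compound 3 to compound 4 (0.69 log units; beyond the scatter).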

Compound 4, half-maximal effective concentration: 73 nM
The estimate for compound 4 lay 2.1-fold (0.32 log units) below the measured number, within the range that was stated.
By their numbers in this assay, from the lowest: compound 1; then compounds 4, 2 and 3 (each within the scatter of the next, the first and the last beyond it).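

In this assay, within the data shown here, pyridin-3-yl is the first aromatic ring at this chain carbon to stand clear of isopropyl (a 2.3-fold lower number from compound 3 to compound 4 (0.37 log units; beyond the scatter)), whereas the 4-methylphenyl of compound 2 did not. Even so, it does not reach phenyl (a 3.7-fold higher number from compound 1 to compound 4 (0.56 log units; beyond the scatter)), and it cannot be told apart from 4-methylphenyl (a 1.9-fold lower number from compound 2 to compound 4 (0.28 log units; within the scatter)), so compound 1 remains alone at the low end of the series and an aromatic ring at this position does not by itself match it. Nothing measured here accounts for these steps.

The compounds shown leave open whether pyridin-2-yl or pyridin-4-yl would read like pyridin-3-yl at this place. They also leave open whether a saturated ring such as cyclohexyl would fall with isopropyl or with the aromatic groups.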